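Swapping the Aryl Group on Selenium in Compound 1

A few compounds are considered here, and "the series" means these few. Any claim that something is new, unique, unknown or untested is made for them only; others in the source may bear on it.

Among the compounds with values here, in a functional assay on SK-MEL-147 cells (Homo sapiens) for cytotoxicity, read by MTT assay, with a stated time of 24 h (a lower number here means that less compound is needed, a higher number that more compound is needed for the effect), compound 1 `CCOC(=O)c1cc([Se]c2ccccc2C)c2cc(OC)ccc2n1` gives 38900 nM, the second highest of the three numbers measured so far. Within the data shown here, compound 3 `CCOC(=O)c1cc([Se]c2ccccc2)c2cc(C)ccc2n1` gives 12000 nM, and compound 2 `CCOC(=O)c1cc([Te]c2ccccc2)c2cc(OC)ccc2n1` gives 128000 nM; the single measured step, a 3.3-fold higher number from compound 1 to compound 2 (0.52 log units; beyond the scatter), exchanges the chalcogen together with its aryl group. Compound 4 `CCOC(=O)c1cc([Se]c2ccc(OC)cc2)c2cc(OC)ccc2n1` differs from compound 1 by 4-methoxyphenyl in place of 2-methylphenyl on a selenium. Among the measured compounds shown here, no measured step alters only the aryl group on the selenium, so the one step recorded bears on this change only loosely, and its modest size suggests no large swing. The expected value for compound 4 is therefore 38900 nM, within 15000 nM to 100000 nM, which amounts to an estimated step of no change at the digits printed from compound 1 to compound 4 (within the scatter), not beyond the scatter.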

Compound 4, half-maximal effective concentration: >= 54300 nM
Compound 4: no number, only a limit; the forecaster's own chance of this, stated with the estimate: 5%; middle value at least 1.3-fold (0.14 log units) away from the limit.
By their numbers in this assay, from the lowest: compound 3; then compound 1; then compound 2.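

In this assay, compound 4 gives a limit and not a number: the limit of >= 54300 nM in this assay, at which 1 of the 4 values shown sits.

This is the only step shown that alters the aryl group on the selenium alone, with 4-methoxyphenyl in place of 2-methylphenyl, and it reads an at least 1.3-fold higher number from compound 1 to compound 4 (0.14 log units; that floor lies within the scatter). It gives only a floor, so the size of the change stays undetermined.

The compounds shown leave open how far this change really reaches. They also leave open whether an aryl group carrying an amine or a carboxylic acid on the selenium would give a lower number in this assay.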